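The source may hold more compounds than are shown below. What is called first, only, known or untested is meant among the compounds shown, and "the series" means these compounds.

Of the compounds shown here, three sharing one core have been tested in a functional assay on B16-F10 cells (Mus musculus) for antiproliferative activity, read by MTT assay, with a stated time of 48 h; a lower number here means a stronger inhibitor, a higher number a weaker inhibitor. Compound 1 `O=C(/C=C/c1ccc(Cl)cc1)Nc1cc(-c2ccc(Br)cc2)[nH]n1` gives 1080 nM in this assay, compound 2 `O=C(/C=C\c1ccc(C(F)(F)F)cc1)Nc1cc(-c2ccccc2)[nH]n1` gives 640 nM, and compound 3 `Cc1ccc(-c2cc(NC(=O)/C=C/c3ccc(C(F)(F)F)cc3)n[nH]2)cc1` gives 1210 nM. Compound 3 thus carries the highest number of the three, yet each gap between these values falls inside the scatter, so the three are not really told apart. Compound 4 `Cc1ccc(-c2cc(NC(=O)/C=C/c3ccc(Br)cc3)n[nH]2)cc1` arises from compound 3 by one change: bromo in place of trifluoromethyl on an aromatic carbon. Within the data shown here, no measured pair shows this change on its own; compound 1 also carries bromo but differs from compound 3 in a second place, so no step can be read from it. The step expected here, a 1.2-fold lower number from compound 3 to compound 4 (0.08 log units; within the scatter), is small and within the scatter in either direction. Compound 4 is therefore estimated at about 1000 nM, likely between 500 nM and 2200 nM.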

Compound 4, half-maximal inhibitory concentration: 1570 nM
Compound 4: middle estimate off by 1.6-fold (0.20 log units), on the low side; the measured number falls inside the stated range.
By their numbers in this assay, from the lowest: compounds 2, 1, 3 and 4 (each within the scatter of the next, the first and the last beyond it).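

Among these compounds, this is the first direct reading of a single change at this position: on an aromatic carbon para to a large group, bromo in place of trifluoromethyl gives a 1.3-fold higher number from compound 3 to compound 4 (0.11 log units; within the scatter) in this assay. The two groups are not told apart here, although one bromine atom replaces 4 heavy atoms. No available evidence explains this result.

Going by these compounds, it remains open whether a different group at this position, such as an amine or a carboxylic acid, would shift the number beyond the scatter. Also open, on these data alone, is whether this same change gives a similar step when the shared core carries different groups elsewhere.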